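This account rests on a few compounds, and the source may have more. Where it says the series, first, only, none or still open, it means among the compounds named here.

Compound 3 `Cc1ccc(NC(=O)CNc2ccc(C(=O)Nc3ccccc3N)cc2)cc1` gives the lowest number of the three measured compounds in a functional assay on the whole organism (Ehrlich cells, Mus musculus) for antiproliferative activity, with a stated time of 24 h, at a dose of 0.2 mmol/kg by the intraperitoneal route; on this read-out lower numbers stand for less inhibition and higher numbers for more inhibition at the one dose given (going by the name of the read-out): compound 3 gives 43.3%, while compound 1 `Nc1ccccc1NC(=O)c1ccc(NCC(=O)Nc2ccc([N+](=O)[O-])cc2)cc1` gives 83.3% and compound 2 `Nc1ccccc1NC(=O)c1ccc(NCC(=O)Nc2cccc([N+](=O)[O-])c2)cc1` gives 67.6%. Compound 4 `COc1ccc(NC(=O)CNc2ccc(C(=O)Nc3ccccc3N)cc2)cc1` differs from compound 3 in one place: methoxy in place of methyl on an aromatic carbon. For the measured compounds named here, no measured step swaps methyl for methoxy. The steps that involve a change on an aromatic carbon are a number 40 percentage points lower from compound 1 to compound 3 (beyond the scatter) and a number 24.3 percentage points lower from compound 2 to compound 3 (beyond the scatter), but each of them removes or introduces nitro, and neither matches the present change. Going by the values given here, with no direct precedent, only a small movement, not beyond the scatter and in no particular direction, is expected. Compound 4 is therefore estimated at 45%, with a range from 25% to 65%, which means an expected step of a number 1.7 percentage points higher from compound 3 to compound 4 (within the scatter).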

Compound 4, a percentage reported as inhibition, in the whole organism at one dose (the size of the read-out at that dose, not a potency): 66.6%
For compound 4 the middle estimate is 21.6 percentage points below the measured one, and the stated range ends below it.
By their numbers in this assay, from the lowest: compound 3; then compounds 4 and 2 (each within the scatter of the next); then compound 1.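

In this assay, a change on this aromatic carbon, para to a large group, matters even without nitro: methoxy in place of methyl gives a number 23.3 percentage points higher from compound 3 to compound 4 (beyond the scatter). Nitro is therefore not needed to reach the level of the 3-nitrophenyl compound, given a number 1 percentage points lower from compound 2 to compound 4 (within the scatter), although the 4-nitrophenyl compound remains apart, with a number 16.7 percentage points lower from compound 1 to compound 4 (beyond the scatter). No measurement here explains these steps. On these data alone, what an amine, a hydroxyl or a chlorine in the same place would give remains open. So does whether the methyl-to-methoxy step would hold on a different core.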